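Bromo for Methoxycarbonyl on the Aryl Ring of Compound 3

A few compounds are considered here, and "the series" means these few. Any claim that something is new, unique, unknown or untested is made for them only; others in the source may bear on it.

Of the compounds shown here, three sharing one core have been tested in a functional assay on K562 cells (Homo sapiens) for inhibition; on this read-out higher numbers stand for weaker inhibition and lower numbers for stronger inhibition. Compound 1 `Cc1ccc(N2C(=O)C=CC2OCC(F)(F)F)cc1` gives 7140 nM, compound 2 `O=C1C=CC(OCC(F)(F)F)N1c1ccc([N+](=O)[O-])cc1` gives 1530 nM, and compound 3 `COC(=O)c1ccc(N2C(=O)C=CC2OCC(F)(F)F)cc1` gives 14700 nM. Compound 3 thus stands highest of the three numbers: its nearest neighbour is compound 1, with a 2.1-fold higher number from compound 1 to compound 3 (0.31 log units; beyond the scatter), and its furthest is compound 2, with a 9.6-fold higher number from compound 2 to compound 3 (0.98 log units; beyond the scatter). Compound 4 `O=C1C=CC(OCC(F)(F)F)N1c1ccc(Br)cc1` has not yet been measured; it differs from compound 3 in one place, (bromo in place of methoxycarbonyl on an aromatic carbon).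

For the measured compounds named here, no measured step introduces a bromo group, so the expectation rests on what is known about the methoxycarbonyl group that leaves. Both steps that put methoxycarbonyl in place of another group raised the number, namely a 2.1-fold higher number from compound 1 to compound 3 (0.31 log units; beyond the scatter) and a 9.6-fold higher number from compound 2 to compound 3 (0.98 log units; beyond the scatter). Taking it away is therefore expected to lower the number in this assay, by an amount that cannot be placed more exactly than somewhere between those two steps. Accordingly, the expected step is a 3.7-fold lower number from compound 3 to compound 4 (0.57 log units; beyond the scatter), a fall beyond the scatter. Compound 4 is estimated at 4000 nM in this assay, within a range from 1500 nM to 12000 nM.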

Compound 4, half-maximal inhibitory concentration: 3270 nM
Estimate against measurement, compound 4: 1.2-fold (0.09 log units) above; the measured number falls inside the stated range.
By their numbers in this assay, from the lowest: compound 2; then compound 4; then compound 1; then compound 3.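

In this assay, for the compounds shown here, bromo at this aromatic carbon gives a 4.5-fold lower number from compound 3 to compound 4 (0.65 log units; beyond the scatter) and so fills the gap in the order of the earlier compounds, with a 2.2-fold lower number from compound 1 to compound 4 (0.34 log units; beyond the scatter) on one side and a 2.1-fold higher number from compound 2 to compound 4 (0.33 log units; beyond the scatter) on the other. The four groups now run from the lowest number to the highest as nitro, bromo, methyl and methoxycarbonyl, and each neighbouring pair is separated by a step beyond the scatter. Exchanging methoxycarbonyl with its two hydrogen-bond acceptors for bromo with none lowers the number, yet compound 2 remains lower than compound 4, and no measurement given here bears on why the groups fall in this order.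

As far as these compounds go, whether chloro or iodo would give a number close to that of bromo, and whether an amine or a carboxylic acid at this aromatic carbon would fall inside the span from nitro to methoxycarbonyl, remains open. From the compounds shown here alone, all four compounds keep the shared core unchanged, so it is also open whether this order would hold if the core itself were altered.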